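This account rests on a few compounds, and the source may have more. Where it says the series, first, only, none or still open, it means among the compounds named here.

Measured compounds:
compound 1 `Cc1cc(N2C(=O)C3=C(CCCC3)C2=O)c(F)cc1NC(=O)c1occc1C`, 145%
compound 2 `Cc1cc(N2C(=O)C3=C(CCCC3)C2=O)c(F)cc1NC(=O)c1ccc(Cl)o1`, 63%

In a functional assay for positive allosteric modulation of metabotropic glutamate receptor 7 (Homo sapiens), read by calcium flux, in the presence of a further agent that is not named here (a lower number here means a smaller maximal response, a higher number a larger maximal response), compound 1 gives 145% and compound 2 gives 63%. Compound 2 stands lowest of the two values shown; its nearest neighbour is compound 1, and the step of a number 82 percentage points lower from compound 1 to compound 2 (beyond the scatter) lies beyond the scatter. Compound 3 `Cc1nc(C(=O)Nc2cc(F)c(N3C(=O)C4=C(CCCC4)C3=O)cc2C)cs1` has not been measured. It differs from compound 2 in one place: 2-methyl-1,3-thiazol-4-yl in place of 5-chlorofuran-2-yl on a carbonyl carbon. For the measured compounds named here, the only measured step that bears on this change is a number 82 percentage points lower from compound 1 to compound 2 (beyond the scatter), which also exchanged the aromatic group on the carbonyl carbon and moved the maximal response by a large amount. Going by the values given here, that step shows that the group on this carbonyl carbon can shift the read-out strongly, but no measured compound carries a 2-methyl-1,3-thiazol-4-yl group, so the direction for compound 3 is open. Compound 3 is therefore expected to fall between the two measured values, with an estimated step of a number 32 percentage points higher from compound 2 to compound 3 (beyond the scatter). The estimate for compound 3 is 95%, expected to range from 45% to 160%.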

Compound 3, largest response reached (reported as percent of maximum), in percent of the reference or control that the assay uses: 97%
Compound 3: middle estimate off by 2 percentage points, on the low side; low and high end bracket the measured number.
By their numbers in this assay, from the lowest: compound 2; then compound 3; then compound 1.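

In this assay the 2-methyl-1,3-thiazol-4-yl group on the carbonyl carbon sets a third, separate level of response, with a number 34 percentage points higher from compound 2 to compound 3 (beyond the scatter) and a number 48 percentage points lower from compound 1 to compound 3 (beyond the scatter). The two furans, each a five-membered aromatic ring with 1 hetero atom, therefore lie on either side of the thiazole ring with 2 hetero atoms, and the number of ring hetero atoms does not order these three compounds. No measurement shown here accounts for this order.

The three compounds change the ring and its substituent together, leaving their separate contributions unresolved. A plain furan-2-yl, a 5-methylfuran-2-yl or an unsubstituted 1,3-thiazol-4-yl on the same carbonyl carbon would bear on that question, and a phenyl ring would test whether a five-membered ring is needed at all.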